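The source may report more compounds than this note shows. Statements on the series, on what has been measured and on what is new or still open speak of the compounds shown alone.

Working notes on the thiazolidinedione series.

Compound 1 `O=C1NC(=O)/C(=C/c2ccc(OCc3csc(-c4ccccc4)n3)cc2)S1` gives 54% in a functional assay on the whole organism (strain Wistar) with Rattus norvegicus as the target, with a stated time of 15 days, at a dose of 100 mg/kg by the oral route; on this read-out higher numbers stand for a stronger effect at the one dose given and lower numbers for a weaker effect. Compound 2 `O=C1NC(=O)/C(=C/c2ccc(OCCSc3nnc(-c4ccccc4)[nH]3)cc2)S1` gives 38.9% in this assay, and compound 3 `O=C1NC(=O)/C(=C/c2ccc(OCCSc3nnc(Cc4ccccc4)[nH]3)cc2)S1` gives 41.9%. Among the compounds with values here, the one single-point step measured so far, a number 3 percentage points higher from compound 2 to compound 3 (within the scatter), stays inside the scatter. Compound 3 therefore stands level with compound 2 on the numbers shown, and beneath compound 1, whose value lies beyond the scatter from that of compound 3; compound 1 differs from compound 3 in more than one place, so no single step can be drawn from it.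

Compound 4 `O=C1NC(=O)/C(=C/c2ccc(OCCSc3nnc(-c4ccc([N+](=O)[O-])cc4)[nH]3)cc2)S1` differs from compound 3 as follows: 4-nitrophenyl in place of benzyl on an aromatic carbon. Within the data shown here, the only step that bears on this position is the one from compound 2 to compound 3, the exchange of phenyl for benzyl, and it moved the read-out by an amount inside the scatter. Among the measured compounds shown here, no measured compound carries a 4-nitrophenyl group at this position, so no measured step speaks to that group directly. On this basis the expectation is no step beyond the scatter, in either direction, and the estimated step of a number 0.1 percentage points higher from compound 3 to compound 4 (within the scatter) is taken as essentially flat. Compound 4 is accordingly expected to give about 42% in this assay, within the range 28% to 56%.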

Compound 4, a percentage reported as activity, at one dose (the size of the read-out at that dose, not a potency): 22.1%
For compound 4 the middle estimate is 19.9 percentage points above the measured one; measured number outside the range, below it.
By their numbers in this assay, from the lowest: compound 4; then compounds 2 and 3 (each within the scatter of the next); then compound 1.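

This position on the five-membered aromatic ring with 3 nitrogen now proves sensitive in this assay: 4-nitrophenyl in place of benzyl gives a number 19.8 percentage points lower from compound 3 to compound 4 (beyond the scatter), and nitro in place of hydrogen on an aromatic carbon gives a number 16.8 percentage points lower from compound 2 to compound 4 (beyond the scatter). Compound 2 and compound 3 lie within the scatter of each other, so the choice between phenyl and benzyl does not separate them, whereas the drop appears in both comparisons and goes with the nitro group on the outer ring. Nothing at hand gives a reason for this drop.

The compounds shown leave open whether the drop belongs to the nitro group alone or would also follow from another group in its place on the outer ring, such as an amine, a methoxy group or a chlorine atom. They also leave open whether a nitro group on the benzyl ring of compound 3 would lower the read-out in the same way, and whether the core of compound 1 would respond like that of compound 2.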